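This account rests on a few compounds, and the source may have more. Where it says the series, first, only, none or still open, it means among the compounds named here.

Measured so far in an assay on HEK293 cells for agonist activity at Toll-like receptor 8 (Homo sapiens), read by a luciferase reporter, with a stated time of 6 h; on this read-out higher numbers stand for an effect only at larger amounts of compound and lower numbers for an effect already at smaller amounts:

Compound 1, `CCCCNc1nc(N)nc2ccn(CC(=O)NC)c12`, gives > 25 uM, which is a limit of the assay and not a number.
Compound 2, `CCCCNc1nc(N)nc2ccn(Cc3ccsc3)c12`, gives > 25 uM, again a limit of the assay.
Compound 3, `CCCCNc1nc(N)nc2ccn(Cc3cn4ccccc4n3)c12`, gives > 25 uM, also a limit of the assay.

The account follows the step from compound 2 to compound 4. Compound 2 stands only at a limit of the assay, and the two further values shown are limits as well: the limit of > 25 uM in this assay, at which 3 of the 3 values shown sit, is where every value shown sits, so nothing shown places compound 2 above or below any other compound.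

Compound 4, `CCCCNc1nc(N)nc2ccn(Cc3cccc(C)n3)c12`, differs from compound 2 in one place: 6-methylpyridin-2-yl in place of thiophen-3-yl on a saturated chain carbon bound to an aromatic nitrogen.

For the measured compounds named here, the only measured step at the same place is a step that the two limits leave unreadable from compound 1 to compound 2, and it bears on the change only in so far as neither of its two compounds reached a readable number. Going by the values given here, no step of known size is therefore available, and no size of step beyond the scatter is expected in this assay in either direction.

The step from compound 2 to compound 4 is estimated as a step that the limit leaves unreadable from compound 2 to compound 4. Compound 4 is accordingly expected to sit near 30 uM, with a range from 5 uM to 150 uM.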

Compound 4, minimum effective concentration: > 25 uM
Compound 4 ended at the assay's limit; the forecaster's own chance of this, stated with the estimate: 70%; the middle value is on the limit's open side.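

In this assay compound 4 gives > 25 uM, which is a limit of the assay and not a number. No step from compound 1 or compound 2 to compound 4 can be read, as all of them stand at one limit: the limit of > 25 uM in this assay, at which 4 of the 4 values shown sit.

The compounds shown leave open how far these groups on the saturated chain carbon differ, and whether any of them gives a readable value.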